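Removing one trifluoromethyl from compound 2

The compounds below may be only part of what the source reports. "The series", "measured", "known", "first", "only" and "open" are said of these compounds alone.

- compound 1 `COc1cc(N2CCN(C(C)=O)CC2)ccc1Nc1ncc(C(F)(F)F)c(N2Cc3cccc(N(C)S(C)(=O)=O)c3C2)n1` gives 3800 nM
- compound 2 `CN(c1cccc2c1CN(c1nc(Nc3cc(C(F)(F)F)cc(C(F)(F)F)c3)ncc1C(F)(F)F)C2)S(C)(=O)=O` gives 10300 nM

In a functional assay on HepG2 cells (Homo sapiens) for antiproliferative activity, read by spectrophotometry, with a stated time of 2 days (a lower number here means a stronger inhibitor of growth, a higher number a weaker inhibitor of growth), compound 2, at 10300 nM, has the higher of the two numbers, a gap beyond the scatter. Compound 3 `CN(c1cccc2c1CN(c1nc(Nc3cccc(C(F)(F)F)c3)ncc1C(F)(F)F)C2)S(C)(=O)=O` differs from compound 2 in one place, with hydrogen in place of trifluoromethyl on an aromatic carbon. For the measured compounds named here, no measured pair shows this change, so the only guide is compound 1, which carries no trifluoromethyl on that ring and gives 3800 nM. The expected 1.6-fold lower number from compound 2 to compound 3 (0.20 log units; within the scatter) is modest, toward a lower number, and may stay within the scatter. For compound 3 the estimate is 6500 nM, with an expected range from 2500 nM to 15000 nM.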

Compound 3, concentration for 50% growth inhibition: > 30000 nM
Compound 3: a limit, no number; the forecaster's own chance of this, stated with the estimate: 10%; middle value at least 4.6-fold (0.66 log units) from the limit.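

In this assay, replacing one trifluoromethyl with hydrogen on this aromatic ring does not give the small shift that might have been expected; instead it produces an at least 2.9-fold higher number from compound 2 to compound 3 (0.46 log units; beyond the scatter). At this carbon, therefore, the trifluoromethyl cannot be removed without a loss of growth inhibition, even though the ring keeps its other trifluoromethyl. Compound 3 carries a limit of the assay, not a number, so the full size of the step stays unknown: the limit of > 30000 nM in this assay, at which 1 of the 3 values shown sits.

As far as these compounds go, whether a chlorine, a methyl or an amine at this carbon would hold the activity of compound 2 stays open. With only hydrogen and trifluoromethyl compared here, the compounds shown cannot say what this position requires.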